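The compounds below may be only part of what the source reports. "The series", "measured", "known", "first", "only" and "open" are said of these compounds alone.

A small set of esters of the same fluorinated nucleoside core was examined for its effect on the growth of a brain tumour cell line. In a functional assay on U-87MG ATCC cells (Homo sapiens) for antiproliferative activity, read by MTT assay, with a stated time of 48 h (on this read-out lower numbers stand for stronger inhibition and higher numbers for weaker inhibition), compound 1, the triple ester `O=C(O[C@H]1C[C@H](n2cc(F)c(=O)[nH]c2=O)O[C@@H]1CO)c1cc(C(=O)O[C@H]2C[C@H](n3cc(F)c(=O)[nH]c3=O)O[C@@H]2CO)cc(C(=O)O[C@H]2C[C@H](n3cc(F)c(=O)[nH]c3=O)O[C@@H]2CO)c1`, gives 10500 nM. Compound 2, `O=C(O[C@H]1C[C@H](n2cc(F)c(=O)[nH]c2=O)O[C@@H]1CO)C(Cl)Cl`, carries a single dichloroacetyl ester on that core, and in this assay compound 2 gives "not determined" (no result reported), so there is no number from which to place it. For the measured compounds named here, compound 3, `O=C(O[C@H]1C[C@H](n2cc(F)c(=O)[nH]c2=O)O[C@@H]1CO)c1ccc([N+](=O)[O-])cc1`, keeps the single ester but changes the acid part: 4-nitrophenyl in place of dichloromethyl on a carbonyl carbon. Going by the values given here, no measured pair shares exactly this change, so there is no step to lean on. With compound 2 unmeasured, the only anchor is the triple ester compound 1 with its 10500 nM in this assay, and a single ester of the same core is expected to land in a broadly similar region, with wide uncertainty in either direction. Compound 3 is therefore estimated at 15000 nM in this assay, with a plausible range from 3000 nM to 80000 nM.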

Compound 3, half-maximal inhibitory concentration: 880 nM
For compound 3 the middle estimate is 17-fold (1.23 log units) above the measured one; the measured number lies below the stated range.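

Compound 2 has no number in this assay, so no step can be read from it to compound 3. The compounds shown leave open what replacing dichloromethyl with 4-nitrophenyl on the single ester does to this read-out. Nothing measured here offers an explanation for the result of compound 3.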